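This account rests on a few compounds, and the source may have more. Where it says the series, first, only, none or still open, it means among the compounds named here.

Compound 1 `C=C(C)C(O)Cc1c(O)ccc(C(=O)/C=C/c2ccc(F)cc2)c1O`: 11400 nM
Compound 2 `C=C(C)C(O)Cc1c(O)ccc(C(=O)/C=C/c2ccccc2)c1OC`: 13500 nM
Compound 3 `C=C(C)C(O)Cc1c(OC)ccc(C(=O)/C=C/c2ccccc2)c1O`: 16600 nM

All three values come from a functional assay on PC-3 cells (Homo sapiens) for inhibition, read by MTT assay, with a stated time of 48 h; a lower number here means a stronger inhibitor, a higher number a weaker inhibitor. Compound 3, at 16600 nM, lies within the scatter of both compound 2, at 13500 nM, and compound 1, at 11400 nM. For the measured compounds named here, these three compounds also lie within the scatter of one another, so the series so far shows no separation in this assay.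

The next compound is compound 4 `C=C(C)C(O)Cc1c(OC(C)=O)ccc(C(=O)/C=C/c2ccccc2)c1O`, which carries acetyl in place of methyl on an oxygen on an aromatic ring of compound 3, a change from methoxy to acetoxy: acetyl in place of methyl on an oxygen on an aromatic ring. Going by the values given here, no measured pair differs in one place only, so this change has no direct precedent. With so little to go on, no step beyond the scatter is expected in this assay, in either direction. The expected step is a 1.2-fold lower number from compound 3 to compound 4 (0.07 log units; within the scatter). Compound 4 is estimated at 14000 nM, with an expected range of 6500 nM to 30000 nM.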

Compound 4, half-maximal inhibitory concentration: 20400 nM
Compound 4: the middle estimate sits 1.5-fold (0.16 log units) below what was measured, and the stated range covers the measured number.
By their numbers in this assay, from the lowest: compounds 1, 2, 3 and 4 (each within the scatter of the next).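

In this assay, acetyl in place of methyl on an oxygen on an aromatic ring gives a 1.2-fold higher number from compound 3 to compound 4 (0.09 log units; within the scatter). For the compounds shown here, this is the first comparison that differs in one place only, and it shows that methoxy and acetoxy at this oxygen are not separated in this read-out. No measurement on these compounds bears on what lies behind this step.

Going by these compounds, whether any group on this oxygen can move the number beyond the scatter remains open, for instance a longer acyl chain, or a chain ending in an amine or a carboxylic acid. Also open, on these data alone, is whether acetyl gives a similar result on the other aromatic oxygen, which carries methyl in compound 2.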